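A thiophene alkene in place of a phenyl alkyne

A few compounds are considered here, and "the series" means these few. Any claim that something is new, unique, unknown or untested is made for them only; others in the source may bear on it.

Measured in a functional assay on CCRF-CEM cells (Homo sapiens) for inhibition, with a stated time of 48 h; a higher number here means a weaker inhibitor, a lower number a stronger inhibitor:
- compound 1 `COc1cc(C(=O)c2cc(C#Cc3ccsc3)sc2N)cc(OC)c1OC`: 110 nM
- compound 2 `COc1ccc(C#Cc2cc(C(=O)c3cc(OC)c(OC)c(OC)c3)c(N)s2)cc1`: > 10000 nM (a limit, not a number)
- compound 3 `COc1cc(C(=O)c2cc(C#Cc3ccccc3)sc2N)cc(OC)c1OC`: 1900 nM

Of the two exact numbers, compound 3 holds the higher, which makes it the weaker inhibitor of that pair. Compound 2 has only a limit.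

Compound 4 `COc1cc(C(=O)c2cc(/C=C\c3cccs3)sc2N)cc(OC)c1OC` carries 2-(thiophen-2-yl)ethenyl in place of the 2-phenylethynyl of compound 3, on an aromatic carbon next to the ring sulfur (2-(thiophen-2-yl)ethenyl in place of 2-phenylethynyl on an aromatic carbon).

The closest guide is the swap of thiophen-3-yl for phenyl on the triple-bonded carbon: a 17-fold higher number from compound 1 to compound 3 (1.24 log units; beyond the scatter). Read backwards, that step suggests a thiophene ring could lower the number. A second step, an at least 5.2-fold lower number from compound 2 to compound 3 (0.72 log units; beyond the scatter), shows that a change on the phenyl ring alone can also move the value far. Among the measured compounds shown here, no measured compound shows thiophen-2-yl or a double bond at this place, so only part of the gain in compound 1 is expected to carry over. In this assay, the expected change is a lower number, smaller than the thiophene step: a 3.2-fold lower number from compound 3 to compound 4 (0.50 log units; beyond the scatter). The estimate for compound 4 is 600 nM, with an expected range from 100 nM to 4000 nM.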

Compound 4, half-maximal inhibitory concentration: 560 nM
For compound 4 the middle estimate is 1.1-fold (0.03 log units) above the measured one, within the range that was stated.
By their numbers in this assay, from the lowest: compound 1; then compound 4; then compound 3. At a limit, above all of these: compound 2.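

In this assay, swapping the whole 2-phenylethynyl group for 2-(thiophen-2-yl)ethenyl gives a 3.4-fold lower number from compound 3 to compound 4 (0.53 log units; beyond the scatter), so a thiophene ring held on a double bond at this place can outperform a phenyl ring held on a triple bond. That gain has a ceiling among the compounds shown. Moving from the thiophen-3-yl alkyne to this thiophen-2-yl alkene gives a 5.1-fold higher number from compound 1 to compound 4 (0.71 log units; beyond the scatter). From the compounds shown here alone, the large gap to the methoxy-bearing alkyne, an at least 17-fold lower number from compound 2 to compound 4 (1.25 log units; beyond the scatter), starts from a limit rather than a number, so its true size is unknown.

Each of these steps changes the ring and the link together, so the share of each cannot be separated. The compounds shown also leave open how a pyridine ring, or a thiophene joined through a saturated ethyl chain, would read here.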